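The source may hold more compounds than are shown below. What is called first, only, known or untested is meant among the compounds shown, and "the series" means these compounds.

Of the compounds shown here, three built on one shared core have been measured in a functional assay on PA-1 cells (Homo sapiens) for cytotoxicity, read by MTT assay, with stated times of 6 h and 48 h; on this read-out lower numbers stand for stronger inhibition and higher numbers for weaker inhibition. Compound 3 (`O=C(/C=C/c1cc(Br)c(Br)[nH]1)c1ccccc1O`) gives 330 nM, the lowest number among them. Compound 1 (`Cn1c(/C=C/C(=O)c2ccccc2O)cc(Br)c1Br`) gives 1250 nM, and hydrogen in place of methyl on the aromatic nitrogen makes for a 3.8-fold lower number from compound 1 to compound 3 (0.58 log units; beyond the scatter). Compound 2 (`Cn1c(/C=C/C(=O)c2ccccc2)cc(Br)c1Br`) gives >= 100000 nM, which is a limit of the assay and not a number.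

Compound 4 (`O=C(/C=C/c1cc(Br)c(Br)[nH]1)c1ccccc1`) has hydrogen in place of hydroxy on an aromatic carbon of compound 3, ortho to a large group: hydrogen in place of hydroxy on an aromatic carbon. The same exchange has been measured only once, as an at least 80-fold higher number from compound 1 to compound 2 (1.90 log units; beyond the scatter), a large step. It was seen with the methyl on the aromatic nitrogen, which compound 3 and compound 4 both lack, so it is a single precedent from a neighbouring background. A large step towards a higher number is therefore expected in this assay, not a change within the scatter. The expected change is a 120-fold higher number from compound 3 to compound 4 (2.08 log units; beyond the scatter). The scale in this series ends at the limit of >= 100000 nM in this assay, at which 1 of the 3 values shown sits, so compound 4 may also return only a limit. If a number is returned, compound 4 is estimated at 40000 nM, with an expected range of 6000 nM to 100000 nM.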

Compound 4, half-maximal inhibitory concentration: >= 100000 nM
Compound 4 was reported as a limit; the forecaster's own chance of this, stated with the estimate: 45%; at least 2.5-fold (0.39 log units) between middle value and limit.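

In this assay, removing the hydroxy also leaves the core without the methyl on the aromatic nitrogen far weaker, with an at least 300-fold higher number from compound 3 to compound 4 (2.48 log units; beyond the scatter), and the value of compound 4 is a limit and not a number. The large step at this position therefore no longer rests on a single precedent from a neighbouring background, since hydrogen in place of hydroxy now points the same way on both cores: the same change on two cores in this assay, an at least 80-fold higher number (1.90 log units; beyond the scatter) from compound 1 to compound 2 and an at least 300-fold higher number (2.48 log units; beyond the scatter) from compound 3 to compound 4; the limit leaves it open whether they differ. Compound 2 and compound 4 each return a limit, so the step between them cannot be read, and the change from methyl to hydrogen on the aromatic nitrogen can be read only with the hydroxy present: the limit of >= 100000 nM in this assay, at which 2 of the 4 values shown sit.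

The compounds shown leave open how large the loss really is on either core, since neither compound without the hydroxy gives a number. They also leave open whether the hydroxy itself is required at this place on the six-membered aromatic ring, or whether another group, such as a methoxy or an amine, could take its place.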